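Cyano in Place of Fluoro on the Aryl Ring

This account rests on a few compounds, and the source may have more. Where it says the series, first, only, none or still open, it means among the compounds named here.

Compound 3 `Fc1ccc(-c2nc3sccn3c2/C=N/OCc2ccc(Cl)c(Cl)c2)cc1` carries a fluoro group on the six-membered aromatic ring of carbon only. In an assay on HepG2 cells for agonist activity at nuclear receptor subfamily 1 group I member 3 (Homo sapiens), read by a luciferase reporter, with a stated time of 23 h (a higher number here means that more compound is needed for the effect, a lower number that less compound is needed), compound 3 gives 670 nM. Within the data shown here, this is the highest of the three numbers measured so far, but every gap to the others lies within the scatter of the assay. Compound 1 `Cc1ccc(-c2nc3sccn3c2/C=N/OCc2ccc(Cl)c(Cl)c2)cc1` gives 490 nM in this assay, and compound 2 `CC(C)c1ccc(-c2nc3sccn3c2/C=N/OCc2ccc(Cl)c(Cl)c2)cc1` gives 590 nM in this assay. The three compounds differ only in the group on that aromatic carbon, and the steps between them are a 1.2-fold higher number from compound 1 to compound 2 (0.08 log units; within the scatter), a 1.4-fold higher number from compound 1 to compound 3 (0.14 log units; within the scatter) and a 1.1-fold higher number from compound 2 to compound 3 (0.06 log units; within the scatter).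

Compound 4 `N#Cc1ccc(-c2nc3sccn3c2/C=N/OCc2ccc(Cl)c(Cl)c2)cc1` differs from compound 3 by cyano in place of fluoro on an aromatic carbon. Among the measured compounds shown here, the steps that bear on this change are those at the same aromatic carbon, where methyl, isopropyl and fluoro all gave numbers within the scatter of one another. Nothing in the data points to a direction, and compound 4 is therefore expected to show a 1.1-fold lower number from compound 3 to compound 4 (0.05 log units; within the scatter), a step not beyond the scatter. The estimate for compound 4 in this assay is 600 nM, with a range from 250 nM to 1500 nM to allow for a change on either side.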

Compound 4, half-maximal effective concentration: 3400 nM
Estimate against measurement, compound 4: 5.7-fold (0.75 log units) below; measured number above the stated range.
By their numbers in this assay, from the lowest: compounds 1, 2 and 3 (each within the scatter of the next); then compound 4.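

At this aromatic carbon, para to a large group, methyl, isopropyl and fluoro had left the numbers within the scatter of one another, so the position looked indifferent to the group it carries. Cyano shows that it is not: in this assay it stands apart from all three, with a 5.1-fold higher number from compound 3 to compound 4 (0.71 log units; beyond the scatter) and a 5.8-fold higher number from compound 2 to compound 4 (0.76 log units; beyond the scatter) as well as a 6.9-fold higher number from compound 1 to compound 4 (0.84 log units; beyond the scatter) and so compound 4 is the least potent of the four. Cyano brings a triple bond and a hydrogen-bond acceptor that fluoro lacks, but no measurement here separates these features or gives a reason for the step.

Going by these compounds, what remains open is whether the loss of potency belongs to cyano alone or extends to other groups at this carbon, such as an amine, a carboxylic acid, a methoxy group or an acetyl group. On these data alone, it is also open whether cyano in place of fluoro would give a step of similar size if another part of the molecule were changed, for example if the two chloro groups on the far ring gave way to hydrogen.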